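Fluoro for hydroxy at the limit of antiproliferative activity

This account rests on a few compounds, and the source may have more. Where it says the series, first, only, none or still open, it means among the compounds named here.

Measured in a functional assay on CCRF-CEM cells (Homo sapiens) for antiproliferative activity, with a stated time of 72 h; a lower number here means that less compound is needed, a higher number that more compound is needed for the effect:
Compound 1 `Cc1cn([C@H]2C[C@H](CF)[C@@H](CO)O2)c(=O)[nH]c1=O`: > 100 uM
Compound 2 `Cc1cn([C@@H]2O[C@H](CO)[C@@H](CF)[C@H]2O)c(=O)[nH]c1=O`: > 100 uM
Compound 3 `Cc1cn([C@@H]2O[C@H](CO)[C@@H](CO)[C@@H]2O)c(=O)[nH]c1=O`: > 100 uM

All three entries are limits of the assay and not numbers. Compound 3 gives only a limit, > 100 uM. The other two compounds also stand at limits, and compound 3 therefore has no number against which it can be placed.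

Compound 4 `Cc1cn([C@@H]2O[C@H](CO)[C@@H](CF)[C@@H]2O)c(=O)[nH]c1=O` has not yet been measured. It differs from compound 3 by fluoro in place of hydroxy on a saturated chain carbon bound to a saturated ring carbon, the change of hydroxymethyl to fluoromethyl. Going by the values given here, the only measured step between two compounds that differ in one place is a step that the two limits leave unreadable from compound 1 to compound 2. That step is a different change, hydroxy in place of hydrogen on a saturated ring carbon, and it offers no size to carry over. What remains is the limit of > 100 uM in this assay, at which 3 of the 3 values shown sit. Among the compounds with values here, on that evidence, no step of known size or direction is expected in this assay, and compound 4 is expected to stay at the same limit. The estimated step is a step that the limit leaves unreadable from compound 3 to compound 4. For compound 4 the expected value is 120 uM, with an estimated range of 40 uM to 300 uM.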

Compound 4, concentration for half-maximal effect: > 100 uM
Compound 4 gave a limit, no number; the forecaster's own chance of this, stated with the estimate: 85%; the middle value does not contradict the limit.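

In this assay compound 4 gives > 100 uM, a limit of the assay and not a number. No step from compound 1, compound 2 or compound 3 to compound 4 can be read: the limit of > 100 uM in this assay, at which 4 of the 4 values shown sit. The compounds shown leave open whether fluoro in place of hydroxy, or the configuration at a saturated ring carbon, changes the concentration needed at all.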